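Shifting the trifluoromethyl group from compound 3 to compound 4

The source may report more compounds than this note shows. Statements on the series, on what has been measured and on what is new or still open speak of the compounds shown alone.

Compound 3 `CN(C(=O)NC(=O)c1ccccc1F)c1nc(C(F)(F)F)c(C(=O)N/N=C/c2ccccc2C(F)(F)F)s1` gives 4.67 ug/mL in a functional assay on BCG823 cells (Homo sapiens) for inhibition, read by MTT assay, with a stated time of 72 h (on this read-out lower numbers stand for stronger inhibition and higher numbers for weaker inhibition), the second highest of three numbers: compound 1 `CN(C(=O)NC(=O)c1ccc(Cl)cc1Cl)c1nc(C(F)(F)F)c(C(=O)N/N=C/c2cccc(C(F)(F)F)c2)s1` gives 6.11 ug/mL, within the scatter of compound 3, while compound 2 `CN(C(=O)NC(=O)c1ccc(C(F)(F)F)cc1)c1nc(C(F)(F)F)c(C(=O)N/N=C/c2cccc(C(F)(F)F)c2)s1` gives 1.84 ug/mL, beyond it. Going by the values given here, the only measured step, a 3.3-fold lower number from compound 1 to compound 2 (0.52 log units; beyond the scatter), changes the group on the carbonyl carbon. Among the compounds with values here, compound 4 `CN(C(=O)NC(=O)c1ccccc1F)c1nc(C(F)(F)F)c(C(=O)N/N=C/c2cccc(C(F)(F)F)c2)s1` instead carries 3-(trifluoromethyl)phenyl in place of 2-(trifluoromethyl)phenyl on a carbon with a double bond to nitrogen, a change at the carbon with the double bond to nitrogen, a position that no measured pair varies. Compounds 1 and 2 both hold the 3-(trifluoromethyl)phenyl there and bracket compound 3, so no step beyond the scatter is expected. Compound 4 is therefore estimated at 3.5 ug/mL, with a range from 1.5 ug/mL to 9 ug/mL, an expected step of a 1.3-fold lower number from compound 3 to compound 4 (0.13 log units; within the scatter).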

Compound 4, half-maximal inhibitory concentration: 16.3 ug/mL
Compound 4: the middle estimate sits 4.7-fold (0.67 log units) below what was measured; measured number outside the range, above it.
By their numbers in this assay, from the lowest: compound 2; then compounds 3 and 1 (each within the scatter of the next); then compound 4.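

In this assay, the carbon with a double bond to nitrogen proves sensitive to the change from 2-(trifluoromethyl)phenyl to 3-(trifluoromethyl)phenyl (a 3.5-fold higher number from compound 3 to compound 4 (0.54 log units; beyond the scatter)), so the two groups are not interchangeable there, at least with 2-fluorophenyl on the carbonyl carbon. With 3-(trifluoromethyl)phenyl held fixed, 2-fluorophenyl on the carbonyl carbon gives the highest number, both against 4-(trifluoromethyl)phenyl (an 8.9-fold higher number from compound 2 to compound 4 (0.95 log units; beyond the scatter)) and against 2,4-dichlorophenyl (a 2.7-fold higher number from compound 1 to compound 4 (0.43 log units; beyond the scatter)). Nothing available accounts for these steps. On these data alone, whether the 3>4 change behaves the same way with other groups on the carbonyl carbon remains open. Also open, as far as these compounds go, is how a phenyl carrying a methoxy group or an amine would behave on the carbon with a double bond to nitrogen.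

Correction to the line above: the phrase "the 3>4 change" should read "this change from 2-(trifluoromethyl)phenyl to 3-(trifluoromethyl)phenyl".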